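A few compounds are considered here, and "the series" means these few. Any claim that something is new, unique, unknown or untested is made for them only; others in the source may bear on it.

Measured compounds:
Compound 1 `CN(Cc1ccc2c(c1)OCCO2)c1cc(=O)c2cc(C(F)(F)F)cc([N+](=O)[O-])c2s1` — in an ADME assay on microsomes from liver (Mus musculus, strain CD-1) for metabolic stability, read by LC-MS, using NADPH, with a stated time of 30 min, tested at 1 uM (a lower number here means that less of the compound is left, a higher number that more of the compound is left), compound 1 gives 6.46%.
Compound 2 `O=C1CN(c2cc(=O)c3cc(C(F)(F)F)cc([N+](=O)[O-])c3s2)CCN1CC1CCCCC1` — compound 2 gives 7.38%.
Compound 3 `CC1COC2(CCN(c3cc(=O)c4cc(C(F)(F)F)cc([N+](=O)[O-])c4s3)CC2)O1` — compound 3 gives 47.4%.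

Compound 1 has the lowest number of the three. Compound 2 sits within the scatter of it, so the two cannot be told apart on these numbers. Compound 3 stands well beyond the scatter above compound 1, so of the three only compound 3 keeps a clearly larger share of material at the end of this assay.

The account now turns to compound 4 `CN(Cc1ccccc1)c1cc(=O)c2cc(C(F)(F)F)cc([N+](=O)[O-])c2s1`, which has not yet been measured. Its difference from compound 1 is phenyl in place of 2,3-dihydro-1,4-benzodioxin-6-yl on a saturated chain carbon bound to a nitrogen on an aromatic ring. Within the data shown here, no measured pair in this set shows the effect of this change, so the expectation rests on the shared core and on how little compound 1 retains. The step from compound 1 to compound 4 is expected to be small, in no direction that goes beyond the scatter, a number 1.5 percentage points higher from compound 1 to compound 4 (within the scatter). Compound 4 is therefore estimated at 8%, within a range from 2% to 25%.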

Compound 4, percent of the compound remaining: 13%
The estimate for compound 4 lay 5 percentage points below the measured number; low and high end bracket the measured number.
By their numbers in this assay, from the lowest: compounds 1, 2 and 4 (each within the scatter of the next); then compound 3.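

Among these compounds, at this position, on a saturated chain carbon bound to a nitrogen on an aromatic ring, phenyl in place of 2,3-dihydro-1,4-benzodioxin-6-yl gives the first step that can be read in this assay: a number 6.5 percentage points higher from compound 1 to compound 4 (within the scatter). The six-membered non-aromatic ring with its 2 hetero atoms can therefore be lost without a change that stands clear of the usual scatter of this assay. Nothing measured here accounts for the size of this step.

The compounds shown leave open whether an amine, a carboxylic acid or a longer chain in place of phenyl at this position would give a step beyond the scatter. Also open, going by these compounds, is how a single methoxy group on the phenyl ring would read in this assay.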